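Swapping Octylsulfanyl for Dimethylamino on the Shared Core

The source may report more compounds than this note shows. Statements on the series, on what has been measured and on what is new or still open speak of the compounds shown alone.

Measured compounds:
compound 1 `CCCNc1nc(N)nc2c1ncn2/C=C1/CC1(CO)CO` gives > 300000 nM
compound 2 `CC(C)CNc1nc(N)nc2c1ncn2/C=C1/CC1(CO)CO` gives > 300000 nM
compound 3 `CCCCCCCCSc1nc(N)nc2c1ncn2/C=C1/CC1(CO)CO` gives > 300000 nM

In an ADME assay on HFF cells (Homo sapiens) for cytotoxicity, with a stated time of 8 days (a higher number here means that more compound is tolerated, a lower number that less compound is tolerated), compound 1 gives > 300000 nM, which is a limit of the assay rather than a number. Compound 2 likewise gives > 300000 nM, also a limit. Compound 3 gives > 300000 nM, again a limit. Compound 3 therefore stands where the other two stand: the limit of > 300000 nM in this assay, at which 3 of the 3 values shown sit.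

Compound 4 `CN(C)c1nc(N)nc2c1ncn2/C=C1/CC1(CO)CO` differs from compound 3 by dimethylamino in place of octylsulfanyl on an aromatic carbon. The steps that change the group on this aromatic carbon, a step that the two limits leave unreadable from compound 1 to compound 3 and a step that the two limits leave unreadable from compound 2 to compound 3, cannot be sized because of the limit of > 300000 nM in this assay, at which 3 of the 3 values shown sit. Among the compounds with values here, no measured step points in either direction, so compound 4 is expected to stay at the limit, with an expected step that the limit leaves unreadable from compound 3 to compound 4. Compound 4 is estimated at 400000 nM, between 150000 nM and 1000000 nM.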

Compound 4, half-maximal cytotoxic concentration: > 300000 nM
Compound 4 ended at the assay's limit (the forecaster's own chance of this, stated with the estimate: 85%); the middle value lies beyond the limit too.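

Within the data shown here, no step from compound 1, compound 2 or compound 3 to compound 4 can be read, because all four compounds share one limit: the limit of > 300000 nM in this assay, at which 4 of the 4 values shown sit. The compounds shown leave open whether any group on this aromatic carbon would give a readable half-maximal cytotoxic concentration.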